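Bromo to Chloro Exchange in a Small Coumarin-Free Series

A few compounds are considered here, and "the series" means these few. Any claim that something is new, unique, unknown or untested is made for them only; others in the source may bear on it.

The account concerns three measured compounds and one that awaits measurement. Compound 1 `O=C1C(=O)N(CCCCn2cc(COc3cc(=O)oc4ccccc34)nn2)c2ccc(Br)cc21` carries a bromo group on the shared core; compound 2 `O=C1C(=O)N(CCCCn2cc(COc3cc(=O)oc4ccccc34)nn2)c2ccc(Cl)cc21` is its chloro counterpart. In a functional assay on PC-3 cells (Homo sapiens) for inhibition, read by sulforhodamine B assay, with a stated time of 48 h, tested at 50 uM (on this read-out lower numbers stand for less inhibition of growth and higher numbers for more inhibition of growth at the one concentration tested), compound 1 gives 13%, and compound 2 gives 14%. The step of a number 1 percentage points higher from compound 1 to compound 2 (within the scatter) arises from the change (chloro in place of bromo on an aromatic carbon). Compound 3 `O=C1C(=O)N(CCCn2cc(COc3cc(=O)oc4ccccc34)nn2)c2ccc(Br)cc21` differs from compound 1 by a shorter chain as well; the difference between the two cores is not broken down here. In this assay compound 3 gives 14%, the same number as compound 2 at the digits shown and within the scatter of compound 1, so none of the three can be set apart from the others.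

Compound 4 `O=C1C(=O)N(CCCn2cc(COc3cc(=O)oc4ccccc34)nn2)c2ccc(Cl)cc21` is the remaining member of the set and is not yet measured. It differs from compound 3 by chloro in place of bromo on an aromatic carbon, the same change that leads from compound 1 to compound 2, made at the same place on the core. Since that change produced only a number 1 percentage points higher from compound 1 to compound 2 (within the scatter), a step of comparable size, a number 1 percentage points higher from compound 3 to compound 4 (within the scatter), is expected from compound 3 to compound 4, an expectation that rests on the step from compound 1 to compound 2 alone. On that basis compound 4 is estimated to give 15% in this assay, most plausibly between 5% and 25%.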

Compound 4, percent growth inhibition at one concentration: 18%
The estimate for compound 4 lay 3 percentage points below the measured number; low and high end bracket the measured number.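

Carried to the core of compound 3, chloro in place of bromo on an aromatic carbon gives, in this assay, a number 4 percentage points higher from compound 3 to compound 4 (within the scatter). Set beside the same exchange on the core of compound 1, the two steps cannot be told apart, so on this read-out the exchange behaves alike on both cores: the same change on two cores in this assay, a number 1 percentage points higher (within the scatter) from compound 1 to compound 2 and a number 4 percentage points higher (within the scatter) from compound 3 to compound 4, 3 percentage points apart, within the scatter of two such steps This agreement is limited, however: both steps lie within the scatter, so the data do not show that exchanging bromo for chloro alters growth inhibition on either core, and two cores that differ only in their chain give no grounds for expecting the same on any other core in the series.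

The compounds shown leave open what other groups at this place on the aromatic ring would give, whether a fluoro group, a methoxy group or an amine would yield a step that stands clear of the scatter. They also leave open whether the exchange would carry over in the same way on a core with a longer chain, or on one where a carboxylic acid replaces part of the linking chain.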